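This account rests on a few compounds, and the source may have more. Where it says the series, first, only, none or still open, it means among the compounds named here.

Series notes. The shared core is common to compound 1 `CCCCc1nc(=O)c(S(=O)(=O)c2ccc(-c3ccnc(NC(=O)C4CC4)c3)cc2)c(O)n1-c1c(OC)cccc1OC`, compound 2 `CCCCc1nc(=O)c(S(=O)(=O)c2ccc(-c3ccc(F)cc3)cc2)c(O)n1-c1c(OC)cccc1OC` and compound 3 `CCCCc1nc(=O)c(S(=O)(=O)c2ccc(-c3cccnc3)cc2)c(O)n1-c1c(OC)cccc1OC`; they differ only in the aryl group carried on the sulfonyl-bearing ring. In an ADME assay for permeability, using PAMPA, at pH 7.4 (on this read-out higher numbers stand for higher permeability and lower numbers for lower permeability), compound 1 gives 11 nm/s, compound 2 gives 132 nm/s and compound 3 gives 6 nm/s. Compound 3 has the lowest of the three numbers; one of the gaps reaching it is small (a 1.8-fold lower number from compound 1 to compound 3 (0.26 log units; within the scatter)), while the other is large (a 22-fold lower number from compound 2 to compound 3 (1.34 log units; beyond the scatter)), as is the gap a 12-fold higher number from compound 1 to compound 2 (1.08 log units; beyond the scatter).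

Compound 4 `CCCCc1nc(=O)c(S(=O)(=O)c2ccc(-c3ccc(F)nc3)cc2)c(O)n1-c1c(OC)cccc1OC` is not yet measured. The change from compound 3 is fluoro in place of hydrogen on an aromatic carbon, read one bond further out as pyridin-3-yl to 6-fluoropyridin-3-yl. Among the measured compounds shown here, no measured step isolates a fluoro for hydrogen exchange; the only step involving a fluorine, a 22-fold lower number from compound 2 to compound 3 (1.34 log units; beyond the scatter), also swaps the ring itself and so bears on the new step only loosely. A modest rise is therefore expected, a 2.0-fold higher number from compound 3 to compound 4 (0.30 log units; within the scatter), and compound 4 is estimated at 12 nm/s, within 4 nm/s to 40 nm/s in this assay.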

Compound 4, apparent permeability: 24 nm/s
Compound 4: the middle estimate sits 2.0-fold (0.30 log units) below what was measured, and the stated range covers the measured number.
By their numbers in this assay, from the lowest: compounds 3 and 1 (each within the scatter of the next); then compound 4; then compound 2.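

In this assay, among the compounds shown here, fluoro in place of hydrogen on an aromatic carbon next to the ring nitrogen is the first single-atom change, and it gives a 4.0-fold higher number from compound 3 to compound 4 (0.60 log units; beyond the scatter). The 6-fluoropyridin-3-yl group places compound 4 between the other aryl groups, with a 2.2-fold higher number from compound 1 to compound 4 (0.34 log units; beyond the scatter) on one side and a 5.5-fold lower number from compound 2 to compound 4 (0.74 log units; beyond the scatter) on the other, so the number stays clearly short of the 4-fluorophenyl compound. The data hold nothing that explains the size of this step.

Going by these compounds, whether a chloro, methyl or amino group on the same carbon would give a similar step remains open, as does the result of a fluoro on another carbon of this ring. Also unsettled is whether the exchange would carry over to the 2-((cyclopropylcarbonyl)amino)pyridin-4-yl group of compound 1.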